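Aryl change from compound 2 to compound 3

A few compounds are considered here, and "the series" means these few. Any claim that something is new, unique, unknown or untested is made for them only; others in the source may bear on it.

Measured in a functional assay on HeLa cells (Homo sapiens) for inhibition, read by MTT assay, with a stated time of 72 h; a lower number here means a stronger inhibitor, a higher number a weaker inhibitor:
- compound 1 `COc1cc(NC(C)CCCNC(=O)Nc2cccc(F)c2)c2ncccc2c1`: 18000 nM
- compound 2 `COc1cc(NC(C)CCCNC(=O)Nc2cccc(Cl)c2)c2ncccc2c1`: 17000 nM

The two values sit together, with a 1.1-fold lower number from compound 1 to compound 2 (0.02 log units; within the scatter). Within the data shown here, compound 2 therefore stands clear of nothing measured so far in this assay. The next structure is compound 3 `COc1cc(NC(C)CCCNC(=O)Nc2ccc(Br)cc2)c2ncccc2c1`, which carries 4-bromophenyl in place of 3-chlorophenyl on an amide-type nitrogen. Among the measured compounds shown here, the single measured step exchanged one halogen for another and left the value within the scatter, so it gives the only guide here. For the measured compounds named here, no measured step covers a change of both halogen and substitution position, which leaves the estimate uncertain. No step beyond the scatter is expected, and the estimated change is a 1.1-fold lower number from compound 2 to compound 3 (0.03 log units; within the scatter). Compound 3 is expected at 16000 nM, with an estimated range of 7000 nM to 32000 nM.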

Compound 3, half-maximal inhibitory concentration: 20000 nM
Compound 3: middle estimate off by 1.3-fold (0.10 log units), on the low side; the measured number falls inside the stated range.
By their numbers in this assay, from the lowest: compounds 2, 1 and 3 (each within the scatter of the next).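

In this assay the exchange of 3-chlorophenyl for 4-bromophenyl on an amide-type nitrogen gives a 1.2-fold higher number from compound 2 to compound 3 (0.07 log units; within the scatter) and the exchange of 3-fluorophenyl for the same group gives a 1.1-fold higher number from compound 1 to compound 3 (0.05 log units; within the scatter) with both steps lying within the scatter. Unlike the earlier swap of one halogen for another, these steps change the halogen and its numbered place on the phenyl ring together, and the values still do not separate. At this nitrogen, the three halogenated phenyl groups shown cannot be told apart in this read-out.

A 3-bromophenyl group would separate the halogen from its place. From the compounds shown here alone, whether a phenyl ring carrying a carboxylic acid or an amine moves the number beyond the scatter stays open.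

No supporting data bear on this result.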